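Shortening the selenium-bound chain on two related cores

A few compounds are considered here, and "the series" means these few. Any claim that something is new, unique, unknown or untested is made for them only; others in the source may bear on it.

Compound 1 `CCCCC[Se]c1nc(NCc2ccccc2)c2ccccc2n1` and compound 3 `C[Se]c1nc(NCc2ccccc2)c2ccccc2n1` share one core. In a functional assay on CCRF-CEM cells (Homo sapiens) for cytotoxicity, read by MTT assay, with a stated time of 72 h (on this read-out higher numbers stand for weaker inhibition of growth and lower numbers for stronger inhibition of growth), compound 1 gives 72500 nM and compound 3 gives 61600 nM. The step between them is a 1.2-fold lower number from compound 1 to compound 3 (0.07 log units; within the scatter), and the structural change behind it is hydrogen in place of butyl on a saturated chain carbon bound to a selenium atom. Compound 2 `CCCCC[Se]c1nc(N)c2cccnc2n1` is built on another core; the difference between the two cores is not broken down here. In this assay compound 2 gives 42800 nM, a number that sits within the scatter of the other two. Compound 4 `C[Se]c1nc(N)c2cccnc2n1` stands to compound 2 as compound 3 stands to compound 1, carrying hydrogen in place of butyl on a saturated chain carbon bound to a selenium atom at the same place, so it is the same change made a second time, once on each core.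

Given that this change left the number essentially unmoved the first time, as shown by a 1.2-fold lower number from compound 1 to compound 3 (0.07 log units; within the scatter), a similar outcome is expected on the core of compound 2, with an estimated step of a 1.1-fold lower number from compound 2 to compound 4 (0.05 log units; within the scatter). Compound 4 is therefore expected to give about 38000 nM, most likely between 17000 nM and 90000 nM.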

Compound 4, concentration for total growth inhibition: > 100000 nM
Compound 4: a limit, no number; the forecaster's own chance of this, stated with the estimate: 5%; middle value at least 2.6-fold (0.42 log units) away from the limit.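

In this assay compound 4 gives > 100000 nM, which is a limit of the assay and not a number. The step is an at least 2.3-fold higher number from compound 2 to compound 4 (0.36 log units; beyond the scatter), so hydrogen in place of butyl on a saturated chain carbon bound to a selenium atom did not behave alike on the two cores: the same change on two cores in this assay, a 1.2-fold lower number (0.07 log units; within the scatter) from compound 1 to compound 3 and an at least 2.3-fold higher number (0.36 log units; beyond the scatter) from compound 2 to compound 4, at least 2.7-fold (0.43 log units) apart, beyond the scatter of two such steps This does not show the true size of the step on the core of compound 2, and one pair of cores gives no rule for the wider series: the limit of > 100000 nM in this assay, at which 1 of the 4 values shown sits.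

The compounds shown leave open how a selenium-bound ethyl or propyl chain would read on either core, so the chain length at which the number starts to move on the core of compound 2 remains unknown. Also open is which part of the difference between the two cores goes with the differing steps, as no compound shown separates that difference into its parts.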